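Thiophen-3-yl to Pyridin-4-yl on the Sulfonylmethyl Arm

This account rests on a few compounds, and the source may have more. Where it says the series, first, only, none or still open, it means among the compounds named here.

Compound 1, `CCOC(=O)C1=CCCCC1S(=O)(=O)Cc1ccccc1Cl`, in a functional assay on RAW264.7 cells (Mus musculus), read by fluorescence; a lower number here means a stronger inhibitor, a higher number a weaker inhibitor: 14 nM; 1200 nM; 11 nM (3 entries)
Compound 2, `CCOC(=O)C1=CCCCC1S(=O)(=O)Cc1cccc(Cl)c1`: 14 nM
Compound 3, `CCOC(=O)C1=CCCCC1S(=O)(=O)Cc1ccsc1`: 105 nM

For the measured compounds named here, compound 3 holds the higher of the two single numbers; compound 2 lies nearest, and the one step that bears here, a 7.5-fold higher number from compound 2 to compound 3 (0.88 log units; beyond the scatter), is modest but beyond the scatter. Compound 1 gives no single number, as the several entries of compound 1 in this assay, 14 nM; 1200 nM; 11 nM (3 entries) shows. Compound 4, `CCOC(=O)C1=CCCCC1S(=O)(=O)Cc1ccncc1`, differs from compound 3 in pyridin-4-yl in place of thiophen-3-yl on a saturated chain carbon bound to a sulfonyl sulfur. One aromatic ring with one hetero atom is swapped for another; the measured step replaced a chlorophenyl, so it guides only loosely. Compound 4 is expected to sit near compound 3 or somewhat higher in this assay, a 1.9-fold higher number from compound 3 to compound 4 (0.28 log units; within the scatter). The estimate for compound 4 is 200 nM, between 50 nM and 800 nM.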

Compound 4, half-maximal inhibitory concentration: 1410 nM
For compound 4 the middle estimate is 7.1-fold (0.85 log units) below the measured one, outside the stated range (above it).
By their numbers in this assay, from the lowest: compound 2; then compound 3; then compound 4.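

Swapping one aromatic ring with one hetero atom for another on a saturated chain carbon bound to a sulfonyl sulfur proves far from neutral, giving a 13-fold higher number from compound 3 to compound 4 (1.13 log units; beyond the scatter) in this assay and showing that this place distinguishes sharply between such rings. For the compounds shown here, measured against the 3-chlorophenyl group, the pyridin-4-yl group gives a 100-fold higher number from compound 2 to compound 4 (2.00 log units; beyond the scatter) as the widest gap among the single numbers. Nothing at hand accounts for this loss.

On these data alone, it remains open whether pyridin-3-yl or an unsubstituted phenyl ring would behave like pyridin-4-yl or like thiophen-3-yl at this place.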